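The compounds below may be only part of what the source reports. "The series", "measured", "known", "first", "only" and "open" are said of these compounds alone.

Values in an in vitro ADME assay on microsomes from liver (Homo sapiens) for metabolic stability, in the presence of a further agent that is not named here (a lower number here means slower removal, a higher number faster removal of the compound), so far
compound 1 `COc1ccc(Cl)cc1Cn1c(C(=O)NCC(C)(C)CO)cc2cc(C#N)ccc21` gives 10 mL.min-1.g-1
compound 2 `COc1ccc(Cl)cc1Cn1c(C(=O)NCC2(CO)CCC2)cc2cc(C#N)ccc21` gives 34 mL.min-1.g-1
compound 3 `Cc1ccc(F)cc1Cn1c(C(=O)NCC2(CO)CCC2)cc2cc(C#N)ccc21` is not yet measured

Of the two measured numbers, compound 2 holds the higher, at 34 mL.min-1.g-1. The gap to the number for compound 1 lies beyond the scatter. Among the measured compounds shown here, the one measured step, a 3.4-fold higher number from compound 1 to compound 2 (0.53 log units; beyond the scatter) and modest in size, lies on the saturated chain carbon bound to an amide-type nitrogen, not at the place that differs in compound 3. Compound 3 differs by 5-fluoro-2-methylphenyl in place of 5-chloro-2-methoxyphenyl on a saturated chain carbon bound to an aromatic nitrogen and carries 5-fluoro-2-methylphenyl in place of 5-chloro-2-methoxyphenyl on a saturated chain carbon bound to an aromatic nitrogen. For the measured compounds named here, no measured step covers this place, so the data give no direction, and a 3.4-fold higher number from compound 1 to compound 2 (0.53 log units; beyond the scatter) serves only as a gauge of size. No step beyond the scatter is therefore expected in this assay for this change. For compound 3 the expected value is 30 mL.min-1.g-1 with an estimated range from 12 mL.min-1.g-1 to 75 mL.min-1.g-1 as its outer ends. The estimate means an expected 1.1-fold lower number from compound 2 to compound 3 (0.05 log units; within the scatter) and stays within the scatter.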

Compound 3, intrinsic clearance in microsomes: 49 mL.min-1.g-1
Estimate against measurement, compound 3: 1.6-fold (0.21 log units) below; the range from low to high includes it.
By their numbers in this assay, from the lowest: compound 1; then compounds 2 and 3 (each within the scatter of the next).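

In this assay, among the compounds shown here, this is the first reading at the aryl group on a saturated chain carbon bound to an aromatic nitrogen: a 1.4-fold higher number from compound 2 to compound 3 (0.16 log units; within the scatter). For the compounds shown here, with the 1-(hydroxymethyl)cyclobutyl group held fixed, 5-fluoro-2-methylphenyl in place of 5-chloro-2-methoxyphenyl therefore gives no step beyond the scatter, although the single step exchanges both the halogen and the methoxy group for methyl, so the two exchanges cannot be read apart. The data at hand offer no account of this result.

On these data alone, whether 5-fluoro-2-methylphenyl gives the same reading alongside the 1-(hydroxymethyl)-1-methylethyl group of compound 1 remains open. Also open, as far as these compounds go, is how this position reads in this assay with an amine or a carboxylic acid on the aromatic ring.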